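The compounds below may be only part of what the source reports. "The series", "measured", "known", "first", "only" and "open" are said of these compounds alone.

Of the compounds shown here, three with a shared core have been measured in a functional assay (aorta) with Oryctolagus cuniculus as the target; on this read-out higher numbers stand for weaker binding and lower numbers for tighter binding. Compound 1 `COc1cc(C(C)=O)ccc1OCCCN1CCC(C(c2ccc(Cl)cc2)c2ccc(Cl)cc2)CC1` gives 2.51 nM, and compound 2 `COc1cc(C(C)=O)ccc1OCCCN1CCC(C(O)(c2ccc(F)c(F)c2)c2ccc(F)c(F)c2)CC1` gives 2.51 nM; these two values are within the scatter of each other, so no order can be read between them. Compound 3 `NC(=O)c1ccc(OCCCN2CCC(C(c3ccc(F)cc3)c3ccc(F)cc3)CC2)cc1` gives 31.6 nM, the highest of the three numbers, standing well beyond the scatter from compound 1 and equally far from compound 2.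

The next compound, compound 4 `COc1ccccc1OCCCN1CCC(C(c2ccc(F)cc2)c2ccc(F)cc2)CC1`, differs from compound 3 in one place: 2-methoxyphenyl in place of 4-carbamoylphenyl on an oxygen on a saturated carbon. The resulting ether bears a 2-methoxyphenyl group, and compounds 1 and 2 both carry a 2-methoxy substituent on the same phenoxy position while standing far lower than compound 3 in this assay. Compound 4 is therefore expected to move toward those lower values, and the step of a 5.3-fold lower number from compound 3 to compound 4 (0.72 log units; beyond the scatter) is estimated to be a decrease beyond the scatter. Compound 4 is estimated to give 6 nM, with a range from 2 nM to 25 nM.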

Compound 4, dissociation constant: 2.51 nM
Estimate against measurement, compound 4: 2.4-fold (0.38 log units) above; the measured number falls inside the stated range.
By their numbers in this assay, from the lowest: compounds 1, 2 and 4 (each within the scatter of the next); then compound 3.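

Going by these compounds alone, compound 3 and compound 4 form the first pair that differs in one place, so the effect of this group can now be read with the rest of the structure held constant. In this assay, 2-methoxyphenyl in place of 4-carbamoylphenyl on the oxygen gives a 13-fold lower number from compound 3 to compound 4 (1.10 log units; beyond the scatter), a large step beyond the scatter, which shows that the read-out responds strongly to the group at this place. No measurement shown explains this step.

The exchange removes the carbamoyl group, with its hydrogen-bond donor, and introduces the methoxy group in a single step, so the contribution of each cannot be separated. The compounds shown leave open what an unsubstituted phenyl, a nitrile or a carboxylic acid at this place would give.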